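The source may report more compounds than this note shows. Statements on the series, on what has been measured and on what is new or still open speak of the compounds shown alone.

Compound 1 `COc1cc(-c2ccnc3cc(-c4ccc(F)cc4)nn23)cc(OC)c1OC`: 4540 nM
Compound 2 `COc1cc(-c2ccnc3cc(-c4ccc(C)c(C)c4)nn23)cc(OC)c1OC`: 391 nM
Compound 3 `COc1cc(-c2ccnc3cc(-c4cn(C)c5ccccc45)nn23)cc(OC)c1OC`: 185 nM

In a functional assay on B16-F0 cells (Mus musculus) for inhibition, read by CCK-8 assay, with a stated time of 48 h (on this read-out lower numbers stand for stronger inhibition and higher numbers for weaker inhibition), compound 1 stands highest of the three numbers, with compound 2 nearest to it and compound 3 furthest from it. Compound 4 `COc1cc(-c2ccnc3cc(-c4ccc(N(C)C)cc4)nn23)cc(OC)c1OC` differs from compound 1 in one place: dimethylamino in place of fluoro on an aromatic carbon. For the measured compounds named here, two measured steps bear on this change, since both also replace the 4-fluorophenyl of compound 1: a 12-fold lower number from compound 1 to compound 2 (1.06 log units; beyond the scatter) and a 25-fold lower number from compound 1 to compound 3 (1.39 log units; beyond the scatter), each a large drop. The group entering in compound 4 is not one of those, so the size is less certain, but the direction is expected to match: a lower number, beyond the scatter. The expected step is a 7.6-fold lower number from compound 1 to compound 4 (0.88 log units; beyond the scatter). Compound 4 is therefore estimated at 600 nM, between 150 nM and 2500 nM.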

Compound 4, half-maximal inhibitory concentration: 702 nM
Compound 4: middle estimate off by 1.2-fold (0.07 log units), on the low side; the range from low to high includes it.
By their numbers in this assay, from the lowest: compound 3; then compounds 2 and 4 (each within the scatter of the next); then compound 1.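

In this assay, exchanging only the fluoro for dimethylamino on the same ring gives a 6.5-fold lower number from compound 1 to compound 4 (0.81 log units; beyond the scatter), so one small group at this place is enough to move the number beyond the scatter. The 4-(dimethylamino)phenyl and 3,4-dimethylphenyl groups cannot be told apart here, with a 1.8-fold higher number from compound 2 to compound 4 (0.25 log units; within the scatter), while the 1-methyl-1H-indol-3-yl group stays ahead, with a 3.8-fold higher number from compound 3 to compound 4 (0.58 log units; beyond the scatter). Nothing measured here explains these differences. Going by these compounds, it remains open whether a primary amine, a methoxy group or a carboxylic acid at this same place would match dimethylamino.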